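The source may hold more compounds than are shown below. What is called first, only, known or untested is meant among the compounds shown, and "the series" means these compounds.

In an assay on cells for binding affinity to Myc proto-oncogene protein (Homo sapiens) (a lower number here means a stronger inhibitor, a higher number a weaker inhibitor), compound 2 `N#Cc1ccc(-c2cc(-c3ccccc3)cc(-c3ccco3)n2)cc1` gives 5000 nM, the lowest of the two numbers reported. Compound 1 `Cn1nncc1-c1cc(-c2ccc(C(N)=O)cc2)cc(-c2ccc(C#N)cc2)n1` gives 40000 nM in this assay, a higher number that lies beyond the scatter. For compound 3 `c1coc(-c2cc(-c3nccs3)cc(-c3ccc(-c4nccs4)cc3)n2)c1` this assay reports only a limit, > 100000 nM (the limit of > 100000 nM in this assay, at which 1 of the 3 values shown sits). Compound 4 `N#Cc1ccc(-c2cc(-c3ccc(C(=O)NN)cc3)cc(-c3ccco3)n2)cc1` has not yet been measured; it differs from compound 2 by aminocarbamoyl in place of hydrogen on an aromatic carbon. Among the compounds with values here, no measured pair in the set shows this change, so the size of the step is uncertain; a modest weakening, within or slightly beyond the scatter, is expected for the step from compound 2 to compound 4 in this assay, a 1.6-fold higher number from compound 2 to compound 4 (0.20 log units; within the scatter). Compound 4 is estimated at 8000 nM, ranging from 2000 nM to 40000 nM.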

Compound 4, half-maximal inhibitory concentration in the Myc proto-oncogene protein assay: > 100000 nM
Compound 4: a limit, no number; the forecaster's own chance of this, stated with the estimate: 10%; middle value at least 12-fold (1.09 log units) from the limit.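

Within the data shown here, at this position, on an aromatic carbon para to a large group, aminocarbamoyl in place of hydrogen gives the first measured step for this change in the Myc proto-oncogene protein assay, and it is large: an at least 20-fold higher number from compound 2 to compound 4 (1.30 log units; beyond the scatter). On these data alone, the reading for compound 4 is a limit, so the full size of the step stays unknown. In a physicochemical assay for solubility, at pH 6 (a higher number here means a more soluble compound, a lower number a less soluble compound), compound 2 gives 2000 nM and compound 4 gives 500000 nM. The same change also shifts solubility: the measured solubility of compound 2, 2000 nM, and of compound 4, 500000 nM, a 250-fold higher number (2.40 log units; beyond the scatter)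

The compounds shown leave open whether an amine or a carboxylic acid at this position would keep the number of compound 2 in the Myc proto-oncogene protein assay. They also leave open whether the loss belongs to aminocarbamoyl alone or to any group placed here.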